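The source may report more compounds than this note shows. Statements on the series, on what has been measured and on what is new or still open speak of the compounds shown alone.

Measured in a functional assay on SGC-7901 cells (Homo sapiens) for antiproliferative activity, read by MTT assay, with a stated time of 72 h; on this read-out higher numbers stand for weaker inhibition and lower numbers for stronger inhibition:
- compound 1 `COc1ccc(-c2ccc3ncn(-c4cc(OC)c(OC)c(OC)c4)c3c2)cc1F`: 430 nM
- compound 2 `COc1cc(-n2cnc3ccc(-c4cccc(C)c4)cc32)cc(OC)c1OC`: 1240 nM

Compound 2, at 1240 nM, holds the higher of the two numbers. Compound 3 `COc1cc(-n2cnc3ccc(-c4cccc(C)c4C)cc32)cc(OC)c1OC` differs from it by methyl in place of hydrogen on an aromatic carbon, ortho to a large group and ortho to a methyl group, turning 3-methylphenyl into 2,3-dimethylphenyl. For the measured compounds named here, one measured step bears on this group: a 2.9-fold higher number from compound 1 to compound 2 (0.46 log units; beyond the scatter), a modest step beyond the scatter, with 3-methylphenyl replacing 3-fluoro-4-methoxyphenyl. Going by the values given here, it is a different exchange, so it offers only a rough size and no direct precedent for adding methyl. A modest shift in this assay is therefore expected, tentatively toward a higher number. The expected change is a 1.5-fold higher number from compound 2 to compound 3 (0.16 log units; within the scatter). For compound 3 the estimate is 1800 nM, with an expected range of 600 nM to 5000 nM.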

Compound 3, half-maximal inhibitory concentration: 3040 nM
Compound 3: the middle estimate sits 1.7-fold (0.23 log units) below what was measured, within the range that was stated.
By their numbers in this assay, from the lowest: compound 1; then compound 2; then compound 3.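

In this assay, methyl on the aromatic carbon ortho to a large group and ortho to a methyl group, turning 3-methylphenyl into 2,3-dimethylphenyl, brings a 2.5-fold higher number from compound 2 to compound 3 (0.39 log units; beyond the scatter) and shows that this carbon does not accept methyl without a change in the read-out. With 2,3-dimethylphenyl in place of 3-fluoro-4-methoxyphenyl, the series shows a 7.1-fold higher number from compound 1 to compound 3 (0.85 log units; beyond the scatter) as its widest gap, so the added methyl leads further from the lowest number and not back toward it. No measurement at hand accounts for this shift.

Open, from the compounds shown here alone, is whether methoxy, fluorine, hydroxyl or an amine on the same aromatic carbon would move the number as methyl does. Also open, going by these compounds, is whether methyl at this place would have a similar effect on the 3-fluoro-4-methoxyphenyl group.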